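Formate ester to free hydroxyl on the cyclohexane core

The compounds below may be only part of what the source reports. "The series", "measured", "known", "first", "only" and "open" are said of these compounds alone.

Compound 3 `O=COC1(C(=O)Nc2ccc([N+](=O)[O-])cc2)CCCCC1` gives 33.8 nM in a functional assay on NFS-60 cells (Mus musculus) for inhibition, read by MTT assay, with a stated time of 72 h; on this read-out lower numbers stand for stronger inhibition and higher numbers for weaker inhibition. Among the three measured compounds it stands second highest: compound 1 `O=C(OC1(C(=O)Nc2ccc([N+](=O)[O-])cc2)CCCCC1)c1ccc(Cl)cc1` gives 10.3 nM, the step of a 3.3-fold higher number from compound 1 to compound 3 (0.52 log units; beyond the scatter) being modest, while compound 2 `O=C(OC1(C(=O)Nc2ccc([N+](=O)[O-])cc2)CCCCC1)c1ccccc1` gives 766 nM, the step of a 23-fold lower number from compound 2 to compound 3 (1.36 log units; beyond the scatter) being large. The remaining measured step, a 74-fold higher number from compound 1 to compound 2 (1.87 log units; beyond the scatter), separates the two aryl esters from each other.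

Compound 4 `O=C(Nc1ccc([N+](=O)[O-])cc1)C1(O)CCCCC1` differs from compound 3 by hydrogen in place of formyl on an oxygen on a saturated carbon. Within the data shown here, no measured step removes the acyl group altogether; the nearest are the two steps that strip the aryl ring from the ester, a 3.3-fold higher number from compound 1 to compound 3 (0.52 log units; beyond the scatter) and a 23-fold lower number from compound 2 to compound 3 (1.36 log units; beyond the scatter), which run in opposite directions and so give no single direction. The present change removes only the formyl group, so a step in this assay smaller than either of those is expected, leaning toward a modest rise in the number, a 1.8-fold higher number from compound 3 to compound 4 (0.25 log units; within the scatter). Compound 4 is accordingly estimated at 60 nM, with a range from 12 nM to 400 nM.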

Compound 4, half-maximal inhibitory concentration: 716 nM
Beside the measured number, compound 4's estimate is 12-fold (1.08 log units) below it; measured number outside the range, above it.
By their numbers in this assay, from the lowest: compound 1; then compound 3; then compounds 4 and 2 (each within the scatter of the next).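

Notes on the acyl group: in this assay the formyl group is not a neutral appendage on the oxygen, since a 21-fold higher number from compound 3 to compound 4 (1.33 log units; beyond the scatter) is a large loss on going to the free hydroxyl. Removing the acyl group does not act alike across the esters: a 1.1-fold lower number from compound 2 to compound 4 (0.03 log units; within the scatter) is within the scatter, so the benzoyl ester and the free hydroxyl cannot be told apart, whereas a 70-fold higher number from compound 1 to compound 4 (1.84 log units; beyond the scatter) is large. Nothing measured here accounts for these steps.

Open, as far as these compounds go, is whether an acetyl ester or a methyl ether on this oxygen, or an amine in place of the hydroxyl, would stay with compound 3 or with compound 4. Also open, from the compounds shown here alone, is whether bromo or methoxy on the benzoyl ring would recover what chloro gives in compound 1.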